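Aryl substituent on the piperidine nitrogen: hydroxy to chloro

The compounds below may be only part of what the source reports. "The series", "measured", "known", "first", "only" and "open" are said of these compounds alone.

Three analogues of one core have been measured in an assay on SK-N-MC cells for inhibition of Neuropeptide Y receptor type 1 (Homo sapiens); a higher number here means a weaker inhibitor, a lower number a stronger inhibitor. Compound 1 `COC(=O)C1=C(C)N=C(C)/C(=C(/O)OC)C1c1cccc(NC(=O)NCCNC2CCN(c3ccccc3C(F)(F)F)CC2)c1` gives 31 nM; compound 2 `COC(=O)C1=C(C)N=C(C)/C(=C(/O)OC)C1c1cccc(NC(=O)NCCNC2CCN(c3ccccc3C#N)CC2)c1` gives 3 nM; compound 3 `COC(=O)C1=C(C)N=C(C)/C(=C(/O)OC)C1c1cccc(NC(=O)NCCNC2CCN(c3ccccc3O)CC2)c1` gives 6 nM. Compound 3 thus sits second highest of the three numbers, separated from compound 2 by a gap within the scatter and from compound 1 by a gap beyond it.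

The next compound, compound 4 `COC(=O)C1=C(C)N=C(C)/C(=C(/O)OC)C1c1cccc(NC(=O)NCCNC2CCN(c3cccc(Cl)c3)CC2)c1`, differs from compound 3 in one place: 3-chlorophenyl in place of 2-hydroxyphenyl on an amine nitrogen in a ring.

Of the measured steps, a 10-fold lower number from compound 1 to compound 2 (1.01 log units; beyond the scatter) and a 5.2-fold lower number from compound 1 to compound 3 (0.71 log units; beyond the scatter) show that exchanging the aromatic substituent on this ring can move this assay by a large margin, while a 2.0-fold higher number from compound 2 to compound 3 (0.30 log units; within the scatter) shows that cyano and hydroxy give numbers within the scatter of each other. None of these steps brings in a chlorophenyl, and none removes the hydrogen-bond donor and acceptor that the 2-hydroxyphenyl carries, so the direction of the present step is not anchored by a measured analogue. Given that compound 1, with a substituent lacking donors and acceptors, gives 31 nM, a moderate rise in the number is expected, a 2.5-fold higher number from compound 3 to compound 4 (0.40 log units; beyond the scatter). For compound 4 the expected value in this assay is 15 nM, with a range from 4 nM to 60 nM.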

Compound 4, half-maximal inhibitory concentration: 8 nM
The estimate for compound 4 lay 1.9-fold (0.27 log units) above the measured number; measured number inside the range.
By their numbers in this assay, from the lowest: compounds 2, 3 and 4 (each within the scatter of the next, the first and the last beyond it); then compound 1.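

In this assay, 3-chlorophenyl in place of 2-hydroxyphenyl on the amine nitrogen in the ring gives a 1.3-fold higher number from compound 3 to compound 4 (0.12 log units; within the scatter) and so stays within the scatter, which shows that a number in this range does not depend on the hydrogen-bond donor and acceptor counted on the group that leaves. The same position also tolerates a change in where the substituent stands on the phenyl ring, although the new group does not fully match the cyano analogue: the comparison with that analogue gives a 2.7-fold higher number from compound 2 to compound 4 (0.43 log units; beyond the scatter) and the comparison with the trifluoromethyl analogue gives a 3.9-fold lower number from compound 1 to compound 4 (0.59 log units; beyond the scatter) as a modest gain that compound 4 retains. No measurement shown here accounts for these numbers.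

Because chlorine replaces hydroxy and the substituent's place on the phenyl ring differs in the same step, the compounds shown cannot separate the contribution of the group from that of its place on the ring. Also open, from the compounds shown here alone, is how this assay responds to an unsubstituted phenyl, or to a phenyl carrying a carboxylic acid or an amine, at this nitrogen.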